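The source may report more compounds than this note shows. Statements on the series, on what has been measured and on what is new or still open speak of the compounds shown alone.

Of the compounds shown here, three sharing one core have been tested in a functional assay on CHO cells for antagonist activity at Orexin receptor type 2 (Homo sapiens), read by FLIPR and calcium flux; a lower number here means a stronger inhibitor, a higher number a weaker inhibitor. Compound 1 `Cc1cccc(NC(=O)CSc2nnc(-c3ccoc3C)n2Cc2ccco2)c1` gives 50.1 nM. Compound 2 `COc1ccccc1NC(=O)CSc1nnc(-c2ccoc2C)n1Cc1ccco1` gives 501 nM, and compound 3 `CC(=O)c1ccc(NC(=O)CSc2nnc(-c3ccoc3C)n2Cc2ccco2)cc1` gives 31.6 nM. Among these three numbers, compound 1 stands second highest: its nearest neighbour is compound 3, a gap that lies within the scatter, and its furthest is compound 2, a gap beyond the scatter.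

The new compound 4 `Cc1occc1-c1nnc(SCC(=O)Nc2ccc(N(C)C)cc2)n1Cc1ccco1` has not yet been measured. It differs from compound 1 in one place: 4-(dimethylamino)phenyl in place of 3-methylphenyl on an amide-type nitrogen. The measured steps that bear on this are the two other swaps on the same amide-type nitrogen. The 2-methoxyphenyl gave a 10-fold higher number from compound 1 to compound 2 (1.00 log units; beyond the scatter), whereas the 4-acetylphenyl gave a 1.6-fold lower number from compound 1 to compound 3 (0.20 log units; within the scatter), and between those two groups the step was a 16-fold lower number from compound 2 to compound 3 (1.20 log units; beyond the scatter). The group entering compound 4 is, like that of compound 3, a 4-substituted phenyl, so the closer precedent is the 4-acetylphenyl.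

Compound 4 is therefore expected to give a number close to that of compound 1, with a 1.0-fold lower number from compound 1 to compound 4 (0.00 log units; within the scatter) not beyond the scatter, because of the small step of a 1.6-fold lower number from compound 1 to compound 3 (0.20 log units; within the scatter). The estimate for compound 4 is 50 nM, with a range from 15 nM to 200 nM.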

Compound 4, inhibition constant: 158 nM
Compound 4: middle estimate off by 3.2-fold (0.50 log units), on the low side; measured number inside the range.
By their numbers in this assay, from the lowest: compounds 3 and 1 (each within the scatter of the next); then compound 4; then compound 2.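

In this assay, dimethylamino in place of acetyl on an aromatic carbon gives a 5.0-fold higher number from compound 3 to compound 4 (0.70 log units; beyond the scatter), so two phenyl groups substituted at the same ring carbon are not interchangeable here: the identity of the substituent matters, not only where it sits. Compound 4 also shows that a 4-substituted phenyl on the amide-type nitrogen can lose ground against the 3-methylphenyl group, with a 3.2-fold higher number from compound 1 to compound 4 (0.50 log units; beyond the scatter), a step beyond the scatter, whereas the 4-acetylphenyl step stayed within it. It still keeps an advantage over the 2-methoxyphenyl group, with a 3.2-fold lower number from compound 2 to compound 4 (0.50 log units; beyond the scatter), which places the 4-(dimethylamino)phenyl group in the middle of the series, and no measurement offered here bears on the cause of these steps.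

The compounds shown leave open how much of the weak result for compound 2 belongs to the methoxy group and how much to its place on the ring, a question that a 4-methoxyphenyl group would address. They also leave open how other groups on that ring carbon, such as a primary amine, a carboxylic acid or a longer alkyl chain, would behave.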